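A few compounds are considered here, and "the series" means these few. Any claim that something is new, unique, unknown or untested is made for them only; others in the source may bear on it.

Compound 3 `Cc1ccc(S(=O)(=O)Nc2ccc3c(c2)C(=O)N(C)C3=O)cc1` stands at the upper edge of what an assay on isolated protein for inhibition of lactase/phlorizin hydrolase (Rattus norvegicus), read by colorimetric assay (on this read-out lower numbers stand for stronger inhibition and higher numbers for weaker inhibition), can report: compound 3 gives > 200000 nM, which is a limit of the assay and not a number. Compound 2 `Cc1ccc(S(=O)(=O)Nc2ccc3c(c2)C(=O)N(CCCCBr)C3=O)cc1` also gives > 200000 nM in this assay, again a limit. Only compound 1 `Cc1ccc(S(=O)(=O)Nc2ccc3c(c2)C(=O)N(CCNc2ccc(O)c(O)c2)C3=O)cc1`, carrying the long side chain on the ring amide nitrogen, reaches a number, 66600 nM. The limit of > 200000 nM in this assay, at which 2 of the 3 values shown sit, leaves the steps from compound 1 readable only one way: an at least 3.0-fold higher number from compound 1 to compound 3 (0.47 log units; beyond the scatter) and an at least 3.0-fold higher number from compound 1 to compound 2 (0.47 log units; beyond the scatter), whereas a step that the two limits leave unreadable from compound 2 to compound 3.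

Compound 4 `Cc1ccc(S(=O)(=O)Nc2ccc3c(c2)C(=O)N(Cc2ccccc2)C3=O)cc1` differs from compound 3 by phenyl in place of hydrogen on a saturated chain carbon bound to an amide-type nitrogen in a ring. The step of an at least 3.0-fold higher number from compound 1 to compound 3 (0.47 log units; beyond the scatter) shows that taking away a side chain that carried an aromatic ring weakened inhibition at least modestly, so bringing an aromatic ring back, here as a plain phenyl rather than the (3,4-dihydroxyphenyl)amino of compound 1, might recover some of that. The step that the two limits leave unreadable from compound 2 to compound 3 offers no guidance either way. Compound 4 is therefore expected to remain near the limit, the expected step being an at least 1.3-fold lower number from compound 3 to compound 4 (0.12 log units; that floor lies within the scatter). The estimate for compound 4 in this assay is 150000 nM, with a range from 40000 nM to 600000 nM.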

Compound 4, half-maximal inhibitory concentration: > 200000 nM
Compound 4: a limit, no number; the forecaster's own chance of this, stated with the estimate: 45%; middle value at least 1.3-fold (0.12 log units) away from the limit.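

A phenyl on the saturated chain carbon bound to the amide-type nitrogen in a ring, the change from methyl to benzyl, leaves compound 4 at a limit in this assay, so a six-membered aromatic ring of carbon alone does not bring a readable number at this position. Against compound 1, the only compound with a number, the result is an at least 3.0-fold higher number from compound 1 to compound 4 (0.47 log units; beyond the scatter), which means the benzyl group does not stand in for the side chain of compound 1, even though both carry such a ring. The steps from compound 2 and compound 3 to compound 4 cannot be read, and these three compounds give no order among themselves: the limit of > 200000 nM in this assay, at which 3 of the 4 values shown sit.

On these data alone, it remains open which part of the side chain of compound 1 goes with its measurable inhibition, the two hydroxyl groups on the ring or the amine in the chain, and a plain phenylamino group on the same chain, or a benzyl group bearing the two hydroxyl groups, would separate the two. As far as these compounds go, it is also open whether a chain amine without any aromatic ring, or a carboxylic acid at the chain end, would give a number at all.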